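The compounds below may be only part of what the source reports. "The series", "measured", "known", "first", "only" and "open" are said of these compounds alone.

In a functional assay on SW480 cells (Homo sapiens) for antiproliferative activity, read by MTT assay, with a stated time of 48 h (a higher number here means a weaker inhibitor, a lower number a stronger inhibitor), compound 1 (`CC(C)=CCC[C@]1(C)/C=C/[C@@H](OC(=O)C=C(C)C)[C@](C)(O)/C=C/C(=O)/C(CN2CCCC2)=C\C1`) gives 310 nM and compound 2 (`CSC(=S)OC/C1=C/C[C@](C)(CCC=C(C)C)/C=C/[C@@H](OC(=O)C=C(C)C)[C@](C)(O)/C=C/C1=O`) gives 390 nM. Going by the values given here, these two values lie within the scatter of each other, so compound 2 has no separate standing on the numbers so far. Compound 3 (`CC(C)=CCC[C@]1(C)/C=C/[C@@H](OC(=O)C=C(C)C)[C@](C)(O)/C=C/C(=O)/C(C(=O)N(C(C)C)C(C)C)=C\C1`) has not yet been measured. It differs from compound 2 as follows: a group of 9 heavy atoms (7 carbon, 1 nitrogen, 1 oxygen; no ring) in place of a group of 6 heavy atoms (3 carbon, 1 oxygen, 2 sulfur; no ring), on a double-bonded ring carbon. The entering group is diisopropylcarbamoyl. Among the compounds with values here, only one measured step bears on this change: a 1.3-fold higher number from compound 1 to compound 2 (0.10 log units; within the scatter). That step concerned a group on a saturated chain carbon bound to a double-bonded ring carbon, whereas diisopropylcarbamoyl sits on the double-bonded ring carbon, so it is a weak guide. With compound 2 as the reference, a small step towards a higher number in this assay is expected, and none clearly beyond the scatter. The expected change is a 1.4-fold higher number from compound 2 to compound 3 (0.15 log units; within the scatter). For compound 3 the estimated value is 550 nM, with an expected range of 180 nM to 2200 nM.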

Compound 3, half-maximal inhibitory concentration: 16000 nM
Estimate against measurement, compound 3: 29-fold (1.46 log units) below; the measured number lies above the stated range.
By their numbers in this assay, from the lowest: compounds 1 and 2 (each within the scatter of the next); then compound 3.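

In this assay the double-bonded ring carbon turns out not to accept every group alike: diisopropylcarbamoyl brings a 41-fold higher number from compound 2 to compound 3 (1.61 log units; beyond the scatter), and in place of (pyrrolidin-1-yl)methyl it brings a 52-fold higher number from compound 1 to compound 3 (1.71 log units; beyond the scatter). The two earlier groups, though very different, both hold a saturated chain carbon on the ring and stay within the scatter of each other, whereas the carbonyl of diisopropylcarbamoyl stands on the ring carbon itself. Nothing measured here accounts for this large step.

The compounds shown do not separate the carbonyl from the two isopropyl groups as the feature that goes with the higher number. A (diisopropylamino)methyl group would keep the isopropyl groups without that carbonyl, and a dimethylcarbamoyl group would keep the carbonyl with smaller groups on nitrogen.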